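Iodo to Methoxy on a Shared Core

The compounds below may be only part of what the source reports. "The series", "measured", "known", "first", "only" and "open" are said of these compounds alone.

In a functional assay on A549 cells (Homo sapiens) for antiproliferative activity, read by MTT assay, with a stated time of 48 h (a higher number here means a weaker inhibitor, a lower number a stronger inhibitor), compound 2 `COc1ccc2nc(NC(c3cn(-c4ccccc4)nc3-c3cccc(I)c3)c3c(O)ccc4ccccc34)sc2c1` gives 39300 nM, and compound 1 `COc1ccc2nc(NC(c3cn(-c4ccccc4)nc3-c3ccc([N+](=O)[O-])cc3)c3c(O)ccc4ccccc34)sc2c1` gives 22500 nM. The two values lie within the scatter of each other, so neither compound can be ranked above the other. Compound 3 `COc1cccc(-c2nn(-c3ccccc3)cc2C(Nc2nc3ccc(OC)cc3s2)c2c(O)ccc3ccccc23)c1` keeps the rest of compound 2 but carries methoxy in place of iodo on an aromatic carbon, meta to a large group: methoxy in place of iodo on an aromatic carbon. Within the data shown here, only one measured step offers any guide. It is a 1.7-fold higher number from compound 1 to compound 2 (0.24 log units; within the scatter), which exchanges 4-nitrophenyl for 3-iodophenyl and stays within the scatter. Among the measured compounds shown here, this single step is indirect evidence, as no measured compound yet carries methoxy at this place. No step beyond the scatter is therefore expected in this assay, and the expected change is a 1.3-fold lower number from compound 2 to compound 3 (0.12 log units; within the scatter). For compound 3 the estimated value is 30000 nM, with an expected range of 12000 nM to 70000 nM.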

Compound 3, half-maximal inhibitory concentration: 88100 nM
The estimate for compound 3 lay 2.9-fold (0.47 log units) below the measured number, and the stated range ends below it.
By their numbers in this assay, from the lowest: compounds 1 and 2 (each within the scatter of the next); then compound 3.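

In this assay, methoxy in place of iodo gives a 2.2-fold higher number from compound 2 to compound 3 (0.35 log units; beyond the scatter) and 3-methoxyphenyl in place of 4-nitrophenyl gives a 3.9-fold higher number from compound 1 to compound 3 (0.59 log units; beyond the scatter), so this aromatic substituent can shift the number beyond the scatter, which the earlier step alone did not show. Both steps are modest, yet they set compound 3 apart as the weakest of the three, while compound 1 and compound 2 still cannot be ranked against each other. Nothing measured here accounts for the shift.

The compounds shown leave open whether any group at this place would give a lower number than compound 1 and compound 2 do. An amine, a carboxylic acid or fluoro on the same aromatic carbon could test whether methoxy is unusual here or whether the number varies more widely.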